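Hydroxymethyl in Place of a Cyanopropyl Chain

The source may hold more compounds than are shown below. What is called first, only, known or untested is meant among the compounds shown, and "the series" means these compounds.

Compound 1 `Cc1onc(NS(=O)(=O)c2ccc(N)cc2)c1I` reports only a limit in an assay on COS-7 cells for displacement of a labelled ligand from Endothelin receptor type B (Sus scrofa) (a higher number here means a weaker inhibitor, a lower number a stronger inhibitor), namely > 1000000 nM.
Compound 2 `COc1cccc(Sc2c(NS(=O)(=O)c3ccc(C(C)(C)C)cc3)noc2CCCC#N)c1` gives 520 nM.
Compound 3 `COc1cccc(Sc2c(NS(=O)(=O)c3ccc(C(C)(C)C)cc3)noc2CCO)c1` gives 430 nM.

Of the two numbers shown, compound 2 has the higher one, with compound 3 nearest; the value of compound 1 is the limit of > 1000000 nM in this assay, at which 1 of the 3 values shown sits. Compound 4 `COc1cccc(Sc2c(NS(=O)(=O)c3ccc(C(C)(C)C)cc3)noc2CO)c1` differs from compound 2 by hydroxy in place of 2-cyanoethyl on a saturated chain carbon bound to an aromatic carbon. Among the compounds with values here, the one measured step that bears on this is a 1.2-fold lower number from compound 2 to compound 3 (0.08 log units; within the scatter), where a nitrile left the same chain and the number hardly moved. Compound 4 now removes the rest of that chain as well, so the expected step is a 1.0-fold lower number from compound 2 to compound 4 (0.02 log units; within the scatter), again not beyond the scatter. Compound 4 is therefore estimated at 500 nM, with a range from 200 nM to 1300 nM.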

Compound 4, half-maximal inhibitory concentration: 560 nM
Estimate against measurement, compound 4: 1.1-fold (0.05 log units) below; the measured number falls inside the stated range.
By their numbers in this assay, from the lowest: compounds 3, 2 and 4 (each within the scatter of the next). At a limit, above all of these: compound 1.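

In this assay the whole chain can go down to hydroxymethyl without a change beyond the scatter (a 1.1-fold higher number from compound 2 to compound 4 (0.03 log units; within the scatter); a 1.3-fold higher number from compound 3 to compound 4 (0.11 log units; within the scatter)). On a saturated chain carbon bound to an aromatic carbon, then, the three chains of compound 2, compound 3 and compound 4 cannot be told apart, so neither the nitrile nor the extra chain length shows an effect here. Nothing measured here accounts for this.

On these data alone, whether an amine or a carboxylic acid in place of the hydroxy would keep the number in this range remains open.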